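Taking the methoxy off compound 3

A few compounds are considered here, and "the series" means these few. Any claim that something is new, unique, unknown or untested is made for them only; others in the source may bear on it.

Compound 3 `CCCSc1nc(N/N=C(\C)c2ccc(OC)cc2)c2nnn(Cc3ccccc3)c2n1` gives > 64000 nM in a functional assay on ECa-109 cells (Homo sapiens) for antiproliferative activity, read by MTT assay, with a stated time of 72 h (on this read-out higher numbers stand for weaker inhibition and lower numbers for stronger inhibition), which is a limit of the assay and not a number. That places it at the limit of > 64000 nM in this assay, at which 2 of the 3 values shown sit. Compound 1 `CCCSc1nc(N/N=C/c2ccc(C)cc2)c2nnn(Cc3ccccc3)c2n1` gives > 64000 nM, also a limit. Within the data shown here, compound 2 `CCCSc1nc(N/N=C(\C)c2ccc(O)cc2)c2nnn(Cc3ccccc3)c2n1` gives 32500 nM, the only true number so far.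

Compound 4 `CCCSc1nc(N/N=C(\C)c2ccccc2)c2nnn(Cc3ccccc3)c2n1` differs from compound 3 by hydrogen in place of methoxy on an aromatic carbon, so 4-methoxyphenyl becomes phenyl. Among the measured compounds shown here, two measured steps bear on this. The first, an at least 1.9-fold higher number from compound 2 to compound 3 (0.29 log units; that floor lies within the scatter), comes from methyl in place of hydrogen on an oxygen on an aromatic ring. The second, an at least 1.9-fold lower number from compound 1 to compound 2 (0.29 log units; that floor lies within the scatter), also touches this end of the molecule. Both are only floors, since each rests on a limit, so neither shows a clear gain or loss. No step beyond the scatter is therefore expected in this assay. The expected size is an at least 1.2-fold lower number from compound 3 to compound 4 (0.10 log units; that floor lies within the scatter), which is a small step at best. Compound 4 is estimated at 50000 nM, with an expected range of 25000 nM to 100000 nM, and it may report only a limit.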

Compound 4, half-maximal inhibitory concentration: 32200 nM
For compound 4 the middle estimate is 1.6-fold (0.19 log units) above the measured one, and the stated range covers the measured number.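

In this assay, among these compounds, the step from hydroxy to hydrogen is the first here that joins two true numbers: a 1.0-fold lower number from compound 2 to compound 4 (0.00 log units; within the scatter). Compound 2 and compound 4 therefore cannot be told apart, and the hydroxy group adds nothing measurable to the modest activity of compound 2. The other two steps read an at least 1.9-fold lower number from compound 3 to compound 4 (0.29 log units; that floor lies within the scatter) and an at least 1.9-fold lower number from compound 1 to compound 4 (0.29 log units; that floor lies within the scatter), and they remain floors within the scatter because each starts from a compound that reports only a limit: the limit of > 64000 nM in this assay, at which 2 of the 4 values shown sit.

On these data alone, the true size of the methoxy step stays unknown, as compound 3 reports only a limit. The compounds shown carry hydrogen, hydroxy, methoxy or methyl at this ring position, so it remains open whether an amine, a carboxylic acid or a chlorine there would move the number beyond the scatter.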